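This account rests on a few compounds, and the source may have more. Where it says the series, first, only, none or still open, it means among the compounds named here.

Four compounds built around an amidine end and a chain of aromatic rings were examined in a functional assay on SNB-19 cells (Homo sapiens) for inhibition, read by sulforhodamine B assay, with a stated time of 48 h; on this read-out lower numbers stand for stronger inhibition of growth and higher numbers for weaker inhibition of growth. Compound 1, `N=C(N)c1ccc(-c2ccc(-c3ccc(F)cc3)o2)o1`, and compound 2, `N=C(N)c1ccc(-c2ccc(-c3ccc(Cl)cc3)o2)o1`, share one core and differ only at a single aromatic carbon. In this assay compound 1 gives 1730 nM, and compound 2 gives 1860 nM. The change between them is fluoro in place of chloro on an aromatic carbon, and it produced a 1.1-fold lower number from compound 2 to compound 1 (0.03 log units; within the scatter), so the two numbers cannot be told apart with confidence.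

Compound 3, `N=C(N)c1ccc(-c2ccc(-c3ccc(Cl)cc3)s2)s1`, carries the same chloro group as compound 2 but is built on a different core; the difference between the two cores is not broken down here. In this assay compound 3 gives 1920 nM, a number that sits together with those of compound 1 and compound 2, none of them separated from the others beyond the usual scatter.

Compound 4, `N=C(N)c1ccc(-c2ccc(-c3ccc(F)cc3)s2)s1`, has not yet been measured. It is related to compound 3 by fluoro in place of chloro on an aromatic carbon, the same change that relates compound 2 to compound 1, made at the same place on the ring. Because the earlier step was a 1.1-fold lower number from compound 2 to compound 1 (0.03 log units; within the scatter), a similarly small step is expected here, estimated as a 1.1-fold lower number from compound 3 to compound 4 (0.03 log units; within the scatter). On that basis compound 4 is expected to give about 1800 nM, with the estimate running from 1000 nM to 3300 nM.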

Compound 4, concentration for 50% growth inhibition: 1970 nM
The estimate for compound 4 lay 1.1-fold (0.04 log units) below the measured number; low and high end bracket the measured number.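

In this assay, putting fluoro in place of chloro on the core of compound 3 gave a 1.0-fold higher number from compound 3 to compound 4 (0.01 log units; within the scatter), so on this core the change has no effect that can be told apart from the usual scatter. Set beside the same change on the core of compound 1, the result agrees with the earlier step: the same change on two cores in this assay, a 1.1-fold lower number (0.03 log units; within the scatter) from compound 2 to compound 1 and a 1.0-fold higher number (0.01 log units; within the scatter) from compound 3 to compound 4, 1.1-fold (0.04 log units) apart, within the scatter of two such steps. This shows that the change carried over between these two cores in the sense that neither step can be read as a real shift, but the agreement is between two steps too small to read, so it does not show that a larger effect would carry over, nor that the same would hold on any other core.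

The compounds shown leave open whether a group other than chloro or fluoro at the same place on the six-membered aromatic ring, such as a methoxy group, a nitrile or an amine, would move the number beyond the scatter on either core. They also leave open what would happen to the number on either core if a carboxylic acid stood in place of the amidine end.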